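Thiocarbamate series: nitro for trichloromethyl at the outer ring

The source may report more compounds than this note shows. Statements on the series, on what has been measured and on what is new or still open speak of the compounds shown alone.

Measured so far:
- Compound 1, `CC(=O)Nc1ccc(OC(=S)Nc2ccc(Oc3ccc(C(Cl)(Cl)Cl)cc3)cc2)cc1`: 9.02 in a physicochemical assay for acid dissociation
- Compound 2, `O=[N+]([O-])c1ccc(Sc2ccc(NC(=S)Oc3ccc(O)cc3)cc2)cc1`: 9.21 in this assay

Compound 1 sits within the scatter of compound 2; the two numbers show no difference that can be read as order. Among the measured compounds shown here, no step between measured compounds touches the change now considered.

Compound 3, `CC(=O)Nc1ccc(OC(=S)Nc2ccc(Oc3ccc([N+](=O)[O-])cc3)cc2)cc1`, follows from compound 1 by nitro in place of trichloromethyl on an aromatic carbon. For the measured compounds named here, no measured step covers this exchange, so the step of a number 0.12 log units lower from compound 1 to compound 3 (within the scatter) is expected to stay small, if anything slightly downward, and not clearly beyond the scatter. Compound 3 is estimated at 8.9, with a range of 8.5 to 9.3.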

Compound 3, acid dissociation constant: 9.04
Compound 3: the middle estimate sits 0.14 log units below what was measured, and the stated range covers the measured number.
By their numbers in this assay, from the lowest: compounds 1, 3 and 2 (each within the scatter of the next).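

In this assay, among the compounds shown here, nitro in place of trichloromethyl on an aromatic carbon gives a number 0.02 log units higher from compound 1 to compound 3 (within the scatter), the first step that can be read between two compounds differing in one place. At this position, para to a large group, 4-(trichloromethyl)phenyl and 4-nitrophenyl therefore cannot be told apart by this read-out. On these data alone, whether an amine or a carboxylic acid at the same position would also stay within the scatter remains open. Nothing at hand bears on why this exchange leaves the number so little moved.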